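The compounds below may be only part of what the source reports. "The series", "measured", "known", "first", "only" and "open" are said of these compounds alone.

Measured so far:
Compound 1, `CC(=O)NC[C@H]1O[C@@H](n2cnc3c(N)nc(F)nc32)[C@H](OC(C)=O)[C@@H]1OC(C)=O`: in an ADME assay on L6 cells (Rattus norvegicus) for inhibition, read by resazurin assay, with a stated time of 72 h (on this read-out lower numbers stand for stronger inhibition and higher numbers for weaker inhibition), compound 1 gives 138000 nM.
Compound 2, `CC(=O)NC[C@H]1O[C@@H](n2cnc3c(N)nc(Cl)nc32)[C@H](OC(C)=O)[C@@H]1OC(C)=O`: compound 2 gives 190000 nM.
Compound 3, `CC(=O)O[C@@H]1[C@H](OC(C)=O)[C@@H](CI)O[C@H]1n1cnc2c(N)nc(F)nc21`: compound 3 gives 6300 nM.

Compound 4, `CC(=O)O[C@@H]1[C@H](OC(C)=O)[C@@H](CI)O[C@H]1n1cnc2c(N)nc(Cl)nc21`, is not yet measured. The core of compound 3 differs from the core of compound 1 as counted here: iodo in place of acetamido on a saturated chain carbon bound to a saturated ring carbon. That difference gave a 22-fold lower number from compound 1 to compound 3 (1.34 log units; beyond the scatter), and compound 3 holds the lowest of the three numbers, its steps to compound 1 and compound 2 both beyond the scatter.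

The change from compound 3 to compound 4 is chloro in place of fluoro on an aromatic carbon. The same change occurs once more among the measured compounds, from compound 1 to compound 2: chloro in place of fluoro on an aromatic carbon. There it gave a 1.4-fold higher number from compound 1 to compound 2 (0.14 log units; within the scatter). The place is the same word for word in both pairs, so this is the same change made on a second core. On that basis a step of similar size is expected for compound 4, namely a 1.3-fold higher number from compound 3 to compound 4 (0.10 log units; within the scatter), resting on the measured step of a 1.4-fold higher number from compound 1 to compound 2 (0.14 log units; within the scatter). Compound 4 is therefore estimated at 8000 nM, with the expected range running from 3000 nM to 20000 nM.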

Compound 4, half-maximal inhibitory concentration: 86000 nM
Compound 4: the middle estimate sits 11-fold (1.03 log units) below what was measured; the measured number lies above the stated range.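

In this assay the chloro for fluoro change does not carry from one core to the other, with a 14-fold higher number from compound 3 to compound 4 (1.14 log units; beyond the scatter) against a far smaller step on the acetamido core: the same change on two cores in this assay, a 1.4-fold higher number (0.14 log units; within the scatter) from compound 1 to compound 2 and a 14-fold higher number (1.14 log units; beyond the scatter) from compound 3 to compound 4, 9.9-fold (1.00 log units) apart, beyond the scatter of two such steps

Read the other way, the iodo for acetamido change also depends on the core, with a 2.2-fold lower number from compound 2 to compound 4 (0.34 log units; beyond the scatter) on the chloro compounds against a much larger step on the fluoro compounds: the same change on two cores in this assay, a 22-fold lower number (1.34 log units; beyond the scatter) from compound 1 to compound 3 and a 2.2-fold lower number (0.34 log units; beyond the scatter) from compound 2 to compound 4, 9.9-fold (1.00 log units) apart, beyond the scatter of two such steps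

Both gaps rest on the same four compounds, so they are one finding seen from two sides: the two changes do not add in this series, and a step measured on one core is a poor guide to the other, though this does not show why, or which of the two cores gives the more typical step.

The compounds shown leave open whether a bromo group on the same aromatic carbon would follow the fluoro or the chloro compounds. Also open, as far as these compounds go, is whether an amine in place of iodo on the saturated chain carbon would show the same dependence on the halogen.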